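From Methoxy to Fluoro: Expecting the Affinity of Compound 4

The source may report more compounds than this note shows. Statements on the series, on what has been measured and on what is new or still open speak of the compounds shown alone.

Measured so far:
Compound 1 `C=CCN1CCc2ccccc2C1c1ccccc1` gives 1300 nM in an assay on isolated protein for binding affinity to Sigma non-opioid intracellular receptor 1 (Rattus norvegicus); a lower number here means a stronger inhibitor, a higher number a weaker inhibitor.
Compound 2 `Clc1ccc(C2NCCc3ccccc32)cc1` gives 3400 nM in this assay.
Compound 3 `COc1ccc(C2NCCc3ccccc32)cc1` gives 2200 nM in this assay.

Compound 3 stands second highest of these three numbers. Its nearest neighbour is compound 2, and the step of a 1.5-fold lower number from compound 2 to compound 3 (0.19 log units; within the scatter) lies within the usual scatter of repeated measurements; compound 1 also lies within the scatter of compound 3, so none of the three can be told apart with confidence.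

Compound 4 `Fc1ccc(C2NCCc3ccccc32)cc1` differs from compound 3 in one place: fluoro in place of methoxy on an aromatic carbon, para to a large group. Among the compounds with values here, only one measured step touches this same position, namely a 1.5-fold lower number from compound 2 to compound 3 (0.19 log units; within the scatter), and it was within the scatter. Chloro and methoxy at this position gave numbers that cannot be distinguished, so the exchange for fluoro is expected to produce no step beyond the scatter in this assay, in either direction.

Compound 4 is therefore estimated to give 2800 nM in this assay, with a range from 1200 nM to 7000 nM. This estimate means an expected step of a 1.3-fold higher number from compound 3 to compound 4 (0.10 log units; within the scatter), small and within the scatter.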

Compound 4, half-maximal inhibitory concentration: 1800 nM
Compound 4: middle estimate off by 1.6-fold (0.19 log units), on the high side; low and high end bracket the measured number.
By their numbers in this assay, from the lowest: compounds 1, 4, 3 and 2 (each within the scatter of the next, the first and the last beyond it).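

The exchange of methoxy for fluoro gives a 1.2-fold lower number from compound 3 to compound 4 (0.09 log units; within the scatter), and the exchange of chloro for fluoro gives a 1.9-fold lower number from compound 2 to compound 4 (0.28 log units; within the scatter), so fluoro can be told apart from neither of the two groups measured before it at this position on the aromatic ring. Together with a 1.5-fold lower number from compound 2 to compound 3 (0.19 log units; within the scatter), this means that all three pairs among chloro, methoxy and fluoro now lie within the scatter, and the three groups cannot be put in any order in this assay. The change from methoxy to fluoro also takes the count from 2 heavy atoms to 1 and from 1 hydrogen-bond acceptor to 0 without giving a readable step, and no measurement on hand speaks to why the numbers stay so close.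

The compounds shown leave open whether any group at this position can give a step beyond the scatter, for example an amine, a carboxylic acid or a longer chain. They also leave open whether a bulkier group such as trifluoromethyl, or a second group on the same ring, would separate from these three.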